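A few compounds are considered here, and "the series" means these few. Any claim that something is new, unique, unknown or untested is made for them only; others in the source may bear on it.

Of the compounds shown here, three sharing one core have been tested in a functional assay on HL-60 cells (Homo sapiens) for antiproliferative activity, read by sulforhodamine B assay, with a stated time of 72 h; on this read-out higher numbers stand for weaker inhibition and lower numbers for stronger inhibition. Compound 1 `Cc1cccc(NC(=S)N/N=C/c2ccc3ccccc3n2)c1` gives > 100000 nM, which is a limit of the assay and not a number. Compound 2 `N#Cc1ccc(NC(=S)N/N=C/c2ccc3ccccc3n2)cc1` gives 4660 nM. Compound 3 `COc1cccc(NC(=S)N/N=C/c2ccc3ccccc3n2)c1` gives 71200 nM, the higher of the two results that are actual numbers. Compound 4 `S=C(N/N=C/c1ccc2ccccc2n1)Nc1cccc(Cl)c1` has not yet been measured, and it differs from compound 3 by a single change, chloro in place of methoxy on an aromatic carbon. Among the measured compounds shown here, no measured step makes this exact swap. The closest is an at least 1.4-fold lower number from compound 1 to compound 3 (0.14 log units; that floor lies within the scatter), where methoxy replaces methyl on an aromatic carbon, and its floor lies within the scatter. The steps of an at least 21-fold lower number from compound 1 to compound 2 (1.33 log units; beyond the scatter) and a 15-fold higher number from compound 2 to compound 3 (1.18 log units; beyond the scatter) are large, but both involve 4-cyanophenyl, a group absent from this change, so they bear on it less directly. A modest move towards a lower number is therefore expected in this assay. The expected step is a 2.0-fold lower number from compound 3 to compound 4 (0.31 log units; beyond the scatter). Compound 4 is estimated at 35000 nM, with an expected range from 8000 nM to 100000 nM.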

Compound 4, half-maximal inhibitory concentration: 28800 nM
Beside the measured number, compound 4's estimate is 1.2-fold (0.08 log units) above it; the range from low to high includes it.
By their numbers in this assay, from the lowest: compound 2; then compound 4; then compound 3. At a limit, above all of these: compound 1.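

In this assay, a change confined to the group on the aromatic carbon meta to a large group now gives a step beyond the scatter without involving 4-cyanophenyl: a 2.5-fold lower number from compound 3 to compound 4 (0.39 log units; beyond the scatter). Chloro also separates from methyl beyond the scatter, an at least 3.4-fold lower number from compound 1 to compound 4 (0.54 log units; beyond the scatter), whereas the floor for methoxy in place of methyl lay within it; compound 1 is at a limit, so this step is only a floor: the limit of > 100000 nM in this assay, at which 1 of the 4 values shown sits. Even so, 3-chlorophenyl does not match 4-cyanophenyl: a 6.2-fold higher number from compound 2 to compound 4 (0.79 log units; beyond the scatter).

Compound 2 differs from the others in both the group and its place on the ring, so the shown compounds do not separate these two factors. As far as these compounds go, it also remains open how an amine or a carboxylic acid at the position held by chloro in compound 4 would read.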